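Amino in place of piperidinyl: expectation for compound 4

The source may report more compounds than this note shows. Statements on the series, on what has been measured and on what is new or still open speak of the compounds shown alone.

Measured so far in a functional assay on RPMI18226 cells (Homo sapiens) for antiproliferative activity, read by sulforhodamine B assay, with a stated time of 48 h, tested at 10 uM; a higher number here means more inhibition at the concentration tested (going by the name of the read-out), a lower number less inhibition:
compound 1 `CN1C/C(=C\c2ccc(Cl)cc2)C(=O)[C@@]2(C1)[C@H](c1ccc(Cl)cc1)CN(C)[C@]21C(=O)Nc2ccccc21` gives 61.5%
compound 2 `O=C(Nc1ccccc1)c1c(-c2ccc(Cl)cc2)cc(-c2ccccc2)nc1N1CCCCC1` gives 13%
compound 3 `Cc1ccc(NC(=O)c2c(-c3ccc(Cl)cc3)cc(-c3ccccc3)nc2N2CCCCC2)cc1` gives 24%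

Compound 2 stands lowest of the three numbers; compound 3 is nearest to it and compound 1 furthest. For the measured compounds named here, the one measured single-point change, from compound 2 to compound 3 with methyl in place of hydrogen on an aromatic carbon, gave a number 11 percentage points higher from compound 2 to compound 3 (beyond the scatter). Compound 4 `Nc1nc(-c2ccccc2)cc(-c2ccc(Cl)cc2)c1C(=O)Nc1ccccc1` differs from compound 2 by amino in place of piperidin-1-yl on an aromatic carbon. Going by the values given here, no measured step exchanges a ring for a small group, so the methyl step carries little weight here; with nothing to set a direction, the expectation in this assay is a step not beyond the scatter. The estimate for compound 4 is 15%, between 0% and 40%, which is expected to mean a number 2 percentage points higher from compound 2 to compound 4 (within the scatter).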

Compound 4, a percentage reported as inhibition, at one concentration (the size of the read-out at that concentration, not a potency): 46%
The estimate for compound 4 lay 31 percentage points below the measured number; the measured number lies above the stated range.
By their numbers in this assay, from the lowest: compound 2; then compound 3; then compound 4; then compound 1.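

Within this assay the aromatic carbon next to the ring nitrogen, ortho to a phenylcarbamoyl group, shows a number 33 percentage points higher from compound 2 to compound 4 (beyond the scatter) with amino in place of piperidin-1-yl. For the compounds shown here, the earlier single-point step concerned only a methyl on an aromatic carbon elsewhere, so this is the first sign that piperidin-1-yl is not required here and that this position strongly affects the number. Nothing available accounts for the size of this step.

As far as these compounds go, whether the loss of the ring or the entering hydrogen-bond donor matters remains open. Methylamino, dimethylamino or morpholin-4-yl at this position would help separate the two.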